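Aryl variation on the fused core: toward compound 3

The source may hold more compounds than are shown below. What is called first, only, known or untested is meant among the compounds shown, and "the series" means these compounds.

Measured so far:
compound 1 `CCCc1ccc(-c2cc(=O)c3c(o2)C(CC)(CC)C(=O)C(CC)=C3O)cc1`: 12.2 uM
compound 2 `CCC1=C(O)c2c(oc(-c3ccc(C)c(F)c3)cc2=O)C(CC)(CC)C1=O`: 2.95 uM

In a functional assay on KBVIN cells (Homo sapiens) for antiproliferative activity, read by sulforhodamine B assay, with a stated time of 3 days (a higher number here means that more compound is needed for the effect, a lower number that less compound is needed), compound 1 gives 12.2 uM and compound 2 gives 2.95 uM. Compound 2 has the lowest number of the two measured compounds, set apart by a 4.1-fold lower number from compound 1 to compound 2 (0.62 log units; beyond the scatter). Compound 3 `CCC1=C(O)c2c(oc(-c3cccc(C)c3C)cc2=O)C(CC)(CC)C1=O` differs from compound 2 in one place: 2,3-dimethylphenyl in place of 3-fluoro-4-methylphenyl on an aromatic carbon. Among the compounds with values here, the single measured step changes the same aryl ring, but neither the group that leaves nor the one that enters here appears in it, so no measured step bears directly on this change. The expected step is a 1.4-fold higher number from compound 2 to compound 3 (0.13 log units; within the scatter), within the scatter. For compound 3 the estimate is 4 uM, ranging from 1.5 uM to 12 uM.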

Compound 3, concentration for half-maximal effect: 0.85 uM
Compound 3: middle estimate off by 4.7-fold (0.67 log units), on the high side; the measured number lies below the stated range.
By their numbers in this assay, from the lowest: compound 3; then compound 2; then compound 1.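

In this assay, this aromatic carbon responds to the aryl substitution pattern even with the heavy-atom count unchanged: 2,3-dimethylphenyl in place of 3-fluoro-4-methylphenyl gives a 3.5-fold lower number from compound 2 to compound 3 (0.54 log units; beyond the scatter), beyond the scatter. Against 4-propylphenyl, the same group gives a 14-fold lower number from compound 1 to compound 3 (1.16 log units; beyond the scatter), so it has the lowest number of the three aryl groups shown.

On these data alone, whether this low number holds when one methyl of 2,3-dimethylphenyl is replaced by a methoxy group or an amine remains open. No evidence is available to explain the gain.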